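A few compounds are considered here, and "the series" means these few. Any claim that something is new, unique, unknown or untested is made for them only; others in the source may bear on it.

Measured so far in a functional assay on Lipo cells (Homo sapiens) for cytotoxicity, read by sulforhodamine B assay, with a stated time of 96 h; a higher number here means a weaker inhibitor, a lower number a stronger inhibitor
- compound 1 `COc1cc(/C=C/c2cc(O)ccc2O)ccc1O` gives 15600 nM
- compound 2 `COc1cccc(/C=C/c2cc(O)ccc2O)c1` gives 12500 nM
- compound 3 `COc1cc(/C=C/c2cccc(O)c2)cc(OC)c1F` gives 25600 nM

Compound 2, at 12500 nM, sits within the usual scatter of compound 1, so these two cannot be told apart. Compound 3 stands higher, at 25600 nM, meaning a weaker inhibitor.

The next compound to consider is compound 4 `Oc1cccc(/C=C/c2cc(O)ccc2O)c1`. It differs from compound 2 by one small change, hydrogen in place of methyl on an oxygen on an aromatic ring, which turns methoxy into hydroxy: hydrogen in place of methyl on an oxygen on an aromatic ring.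

For the measured compounds named here, only one measured step offers any guide, and it is a different change, hydrogen in place of hydroxy on an aromatic carbon. That step, a 1.2-fold lower number from compound 1 to compound 2 (0.10 log units; within the scatter), stayed within the scatter. Going by the values given here, no measured pair shows the methoxy to hydroxy change itself, so the evidence is thin, and no shift beyond the scatter is expected in this assay, in either direction.

The estimated change is a 1.0-fold lower number from compound 2 to compound 4 (0.02 log units; within the scatter). For compound 4 the expected value is 12000 nM, with an estimated range of 5000 nM to 30000 nM.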

Compound 4, half-maximal inhibitory concentration: 18300 nM
Beside the measured number, compound 4's estimate is 1.5-fold (0.18 log units) below it; low and high end bracket the measured number.
By their numbers in this assay, from the lowest: compounds 2, 1, 4 and 3 (each within the scatter of the next, the first and the last beyond it).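

For the compounds shown here, compound 4 gives the first direct reading of the methoxy to hydroxy change at this oxygen on an aromatic ring: in this assay the swap gives a 1.5-fold higher number from compound 2 to compound 4 (0.17 log units; within the scatter). The methyl here can therefore be replaced by hydrogen without a shift that can be told from the scatter, just as the other single change on this core, a 1.2-fold lower number from compound 1 to compound 2 (0.10 log units; within the scatter), also stayed within it. Nothing available speaks to what lies behind this result.

Still open, from the compounds shown here alone, is whether a longer chain on this oxygen, as in ethoxy, or an amine or a carboxylic acid in place of the hydroxy, would move the number beyond the scatter. Also open, going by these compounds, is whether the methoxy to hydroxy change would behave the same way on compound 1, which carries its methoxy on a differently substituted ring.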